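Series notes: compound 4, methylthiazolyl in place of methylfuranyl

A few compounds are considered here, and "the series" means these few. Any claim that something is new, unique, unknown or untested is made for them only; others in the source may bear on it.

Three members of the series are measured so far in a functional assay with Alpha-1A adrenergic receptor (Homo sapiens) as the target, read by calcium flux; a higher number here means a larger maximal response, a lower number a smaller maximal response: compound 1 `c1cnc(-c2ccccc2OCC2=NCCN2)nc1` gives 90%, compound 2 `c1ccc(-c2ccns2)c(OCC2=NCCN2)c1` gives 99% and compound 3 `Cc1ccoc1-c1ccccc1OCC1=NCCN1` gives 99%. Compound 3 sits level with compound 2 at the digits given, and the step of a number 9 percentage points higher from compound 1 to compound 3 (within the scatter) does not stand out. Compound 4 `Cc1cnsc1-c1ccccc1OCC1=NCCN1` differs from compound 3 by 4-methyl-1,2-thiazol-5-yl in place of 3-methylfuran-2-yl on an aromatic carbon. The most closely related measured step is no change at the digits printed from compound 2 to compound 3 (within the scatter), which set 3-methylfuran-2-yl against 1,2-thiazol-5-yl; the remaining steps, a number 9 percentage points higher from compound 1 to compound 2 (within the scatter) and a number 9 percentage points higher from compound 1 to compound 3 (within the scatter), also stay inside the scatter. Nothing in these numbers points to a shift beyond the scatter, so the expected step is a number 2 percentage points lower from compound 3 to compound 4 (within the scatter). For compound 4 the maximal response in this assay is estimated at 97%, expected to fall between 85% and 109%.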

Compound 4, largest response reached (reported as maximum), in percent of the reference or control that the assay uses: 104%
Compound 4: the middle estimate sits 7 percentage points below what was measured; low and high end bracket the measured number.
By their numbers in this assay, from the lowest: compounds 1, 2, 3 and 4 (each within the scatter of the next, the first and the last beyond it).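

In this assay, 4-methyl-1,2-thiazol-5-yl in place of 3-methylfuran-2-yl gives a number 5 percentage points higher from compound 3 to compound 4 (within the scatter), and methyl in place of hydrogen on an aromatic carbon gives a number 5 percentage points higher from compound 2 to compound 4 (within the scatter), so neither change separates these compounds. Against pyrimidin-2-yl, the same 4-methyl-1,2-thiazol-5-yl gives a number 14 percentage points higher from compound 1 to compound 4 (beyond the scatter), the first step in the series to pass the scatter. No available evidence bears on this step.

Open, going by these compounds, is whether an amine or a carboxylic acid at this place on the six-membered aromatic ring, or a longer chain in place of the methyl, would keep the maximal response.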